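The source may hold more compounds than are shown below. What is called first, only, known or untested is meant among the compounds shown, and "the series" means these compounds.

Measured compounds:
- compound 1 `CC(C)(C)OC(=O)CCC(Nc1ccc(CN(CCCc2c(N)nc(N)nc2O)c2cc(F)cc(F)c2[N+](=O)[O-])cc1)C(=O)OC(C)(C)C`: 17000 nM
- compound 2 `Nc1nc(N)c(CCCNc2cc(F)c(F)cc2[N+](=O)[O-])c(O)n1`: > 100000 nM (a limit of the assay)

The two compounds were tested in a functional assay on CCRF-CEM cells (Homo sapiens) for cytotoxicity, in the absence of a further agent; on this read-out higher numbers stand for weaker inhibition and lower numbers for stronger inhibition. For the measured compounds named here, on this read-out, compound 1 gives 17000 nM, which is the only actual number available. For compound 2 the result of > 100000 nM is a limit of the assay and not a number.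

The next compound to consider is compound 3 `CC(C)(C)OC(=O)CCC(Nc1ccc(CN(CCCc2c(N)nc(N)nc2O)c2cc(F)c(F)cc2[N+](=O)[O-])cc1)C(=O)OC(C)(C)C`, which has not yet been measured. It has the same atoms as compound 1, joined differently, with 4,5-difluoro-2-nitrophenyl in place of 3,5-difluoro-2-nitrophenyl on an amine nitrogen. Going by the values given here, no measured pair of close relatives shows how large such an exchange can be, so the expectation rests on compound 1 at 17000 nM and on the close match of the two groups. No shift beyond the scatter is expected in this assay, in either direction. The expected change is a 1.1-fold lower number from compound 1 to compound 3 (0.05 log units; within the scatter). For compound 3 the estimated value is 15000 nM, with an expected range from 4000 nM to 60000 nM.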

Compound 3, half-maximal inhibitory concentration: 3400 nM
The estimate for compound 3 lay 4.4-fold (0.64 log units) above the measured number; measured number outside the range, below it.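

In this assay the arrangement of the two fluorines on the nitrophenyl ring proves to matter: 4,5-difluoro-2-nitrophenyl in place of 3,5-difluoro-2-nitrophenyl on an amine nitrogen gives a 5.0-fold lower number from compound 1 to compound 3 (0.70 log units; beyond the scatter), a step beyond the scatter. For the compounds shown here, the two groups have the same atoms and the same counts of hydrogen-bond donors and acceptors, so this single exchange shows that the read-out responds to how the group is joined, not only to what it contains, which the earlier compounds, with no comparable pair among them, could not show. Nothing in the data shown explains why this exchange lowers the number.

Compound 2 also carries the 4,5-difluoro-2-nitrophenyl group and gives > 100000 nM, which is a limit of the assay and not a number. From the compounds shown here alone, it remains open whether a ring with a single fluorine or with chlorine in place of fluorine would follow compound 3, and whether the step would persist with free carboxylic acids in place of the esters of the shared core.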